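This account rests on a few compounds, and the source may have more. Where it says the series, first, only, none or still open, it means among the compounds named here.

Measured compounds in an assay on isolated protein for displacement of a labelled ligand from Gonadotropin-releasing hormone receptor (Rattus norvegicus); a higher number here means a weaker inhibitor, a lower number a stronger inhibitor:

compound 1 `CCc1nc(C)c(CN2CCN(c3cccc4[nH]c(-c5ccc(C(C)(C)C)cc5)nc34)CC2)s1`, giving 120 nM
compound 2 `CCCCn1cnc(CN2CCN(c3cccc4[nH]c(-c5ccc(C(C)(C)C)cc5)nc34)CC2)c1C`, giving 49 nM
compound 3 `CCc1nc(CN2CCN(c3cccc4[nH]c(-c5ccc(C(C)(C)C)cc5)nc34)CC2)cn1C`, giving 78 nM

All three share the same core and differ only in the five-membered aromatic ring carried on the saturated chain carbon bound to an amine nitrogen in a ring. For the measured compounds named here, on the numbers so far compound 3 stands second highest of the three; its nearest neighbour is compound 1, and the gap between them, a 1.5-fold lower number from compound 1 to compound 3 (0.19 log units; within the scatter), lies within the scatter. The step of a 1.6-fold higher number from compound 2 to compound 3 (0.20 log units; within the scatter) is likewise within the scatter, so the imidazole variants in hand do not separate from one another. Only a 2.4-fold lower number from compound 1 to compound 2 (0.39 log units; beyond the scatter) is modest but beyond the scatter.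

Compound 4 `CCn1cc(CN2CCN(c3cccc4[nH]c(-c5ccc(C(C)(C)C)cc5)nc34)CC2)nc1C` is not yet measured. Its difference from compound 3 is 1-ethyl-2-methyl-1H-imidazol-4-yl in place of 2-ethyl-1-methyl-1H-imidazol-4-yl on a saturated chain carbon bound to an amine nitrogen in a ring. The two have the same atoms, joined differently: the ethyl and methyl groups trade places on the imidazole. Going by the values given here, no measured step covers exactly this rearrangement. Among the compounds with values here, the closest precedent is the step from compound 2 to compound 3, which rearranged alkyl groups on the imidazole without moving beyond the scatter, and the step from compound 1 to compound 3, also within the scatter.

A step of a 1.0-fold lower number from compound 3 to compound 4 (0.02 log units; within the scatter) in this assay is therefore expected, meaning no change beyond the scatter. For compound 4 the estimate in this assay is 75 nM, with a range from 30 nM to 190 nM.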

Compound 4, half-maximal inhibitory concentration: 51 nM
Compound 4: middle estimate off by 1.5-fold (0.17 log units), on the high side; the range from low to high includes it.
By their numbers in this assay, from the lowest: compounds 2, 4, 3 and 1 (each within the scatter of the next, the first and the last beyond it).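

Working notes on the group on the saturated chain carbon bound to an amine nitrogen in a ring: in this assay, trading the places of ethyl and methyl on the imidazole, with the same atoms joined differently, gives a step within the scatter (a 1.5-fold lower number from compound 3 to compound 4 (0.18 log units; within the scatter)), and 1-ethyl-2-methyl-1H-imidazol-4-yl also does not separate from 1-butyl-5-methyl-1H-imidazol-4-yl (a 1.0-fold higher number from compound 2 to compound 4 (0.02 log units; within the scatter)). Against 2-ethyl-4-methyl-1,3-thiazol-5-yl, compound 4 now joins compound 2 in lying beyond the scatter, though only modestly (a 2.4-fold lower number from compound 1 to compound 4 (0.37 log units; beyond the scatter)), while compound 3 remains the imidazole that goes against this pattern, since its step from the thiazole stays within the scatter (a 1.5-fold lower number from compound 1 to compound 3 (0.19 log units; within the scatter)). No measurement shown here accounts for any of these steps.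

Across the imidazoles shown, the placement and length of simple alkyl groups at this position have yet to give a step beyond the scatter, so it remains open how far this tolerance extends. Whether a carboxylic acid, a primary amine or a hydroxyl on the ring, or a phenyl ring in place of the imidazole, would shift the number is also unresolved.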